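The compounds below may be only part of what the source reports. "The series", "measured", "known", "first", "only" and "open" are said of these compounds alone.

compound 1 `CCN(C)c1nc(Cc2c(F)cccc2F)c(C)c(=O)[nH]1` gives > 85000 nM as a limit
compound 2 `CCCN(C)c1nc(Cc2c(F)cccc2F)c(C)c(=O)[nH]1` gives > 81000 nM as a limit
compound 3 `Cc1c(Cc2c(F)cccc2F)nc(N(C)C2CCCCC2)[nH]c1=O` gives > 72000 nM as a limit

All three readings come from an ADME assay on MT4 cells (Homo sapiens) for cytotoxicity, read by MTT assay, with a stated time of 4 days (on this read-out lower numbers stand for higher toxicity in this test and higher numbers for lower toxicity in this test), and none of them is an exact number. Among the measured compounds shown here, compound 3 stands at a limit with > 72000 nM as its only reading.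

Compound 4 `CCN(CC)c1nc(Cc2c(F)cccc2F)c(C)c(=O)[nH]1` differs from compound 3 at one place on the shared core (diethylamino in place of cyclohexyl(methyl)amino on an aromatic carbon) with diethylamino in place of cyclohexyl(methyl)amino on an aromatic carbon.

Three measured steps change this same amino group. With sizes unreadable in a step that the two limits leave unreadable from compound 1 to compound 2 and a step that the two limits leave unreadable from compound 1 to compound 3 and a step that the two limits leave unreadable from compound 2 to compound 3 there is no measured size to carry over, so no step beyond the usual scatter is expected in this assay here.

The expected change is a step that the limit leaves unreadable from compound 3 to compound 4 in size. Compound 4 is estimated at 78000 nM with an expected range of 45000 nM to 90000 nM and will probably also be reported as a limit.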

Compound 4, half-maximal cytotoxic concentration: > 81000 nM
Compound 4: only a limit was reported; the forecaster's own chance of this, stated with the estimate: 85%; middle value at least 1.0-fold (0.01 log units) from the limit.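

Compound 4, like compound 1, compound 2 and compound 3, is reported only as a limit in this assay, so its steps to them cannot be read. The compounds shown leave open the concentration at which any of them becomes toxic to these cells.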